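Working notes: amide substituent change and cytotoxicity

A few compounds are considered here, and "the series" means these few. Any claim that something is new, unique, unknown or untested is made for them only; others in the source may bear on it.

Measured compounds:
compound 1 `O=C(NCC1CCCCC1)c1cccc(/C=C2\CC(=O)N(c3ccccc3)C2=O)c1` — in an ADME assay on NCM460 cells (Homo sapiens) for cytotoxicity, read by MTT assay, with a stated time of 72 h (on this read-out lower numbers stand for stronger inhibition and higher numbers for weaker inhibition), compound 1 gives > 100000 nM, a limit of the assay and not a number.
compound 2 `CCc1cccc(NC(=O)c2cccc(/C=C3\CC(=O)N(Cc4ccccc4)C3=O)c2)c1` — compound 2 gives > 100000 nM, again a limit.
compound 3 `O=C(Nc1ccc(Cl)cc1)c1cccc(/C=C2\CC(=O)N(Cc3ccccc3)C2=O)c1` — compound 3 gives > 100000 nM, again a limit.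

Where compound 1 stands: only a limit is known for compound 1, and the two further values shown are limits as well, so compound 1 cannot be placed above or below any other member of the series. All three values sit at the limit of > 100000 nM in this assay, at which 3 of the 3 values shown sit.

The step to be followed leads to compound 4 `Cc1cccc(NC(=O)c2cccc(/C=C3\CC(=O)N(c4ccccc4)C3=O)c2)c1`. The change is 3-methylphenyl in place of cyclohexylmethyl on an amide-type nitrogen. Within the data shown here, the one measured step that touches a change on the same amide-type nitrogen is a step that the two limits leave unreadable from compound 2 to compound 3, and its size is not readable because both ends sit at the limit of > 100000 nM in this assay, at which 3 of the 3 values shown sit. Nothing in the measured set therefore gives a direction or a size for the present change, and no step beyond the scatter can be expected.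

Compound 4 is estimated to sit at the limit as well, around 150000 nM, within 60000 nM to 400000 nM. The estimated step that the limit leaves unreadable from compound 1 to compound 4 is expected to be no more than an unreadable one between two limits.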

Compound 4, half-maximal inhibitory concentration: > 100000 nM
Compound 4 gave a limit, no number; the forecaster's own chance of this, stated with the estimate: 85%; the middle value lies beyond the limit too.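

Compound 4 gives > 100000 nM in this assay, a limit and not a number. No step can be read from compound 1 to compound 4, because both sit at the same limit: the limit of > 100000 nM in this assay, at which 4 of the 4 values shown sit.

The compounds shown leave open whether any substituent on the amide-type nitrogen gives a measurable value in this assay.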